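The compounds below may be only part of what the source reports. "The series", "measured", "known", "first", "only" and "open" are said of these compounds alone.

Going by the values given here, in a physicochemical assay for lipophilicity (a lower number here means a more polar compound, a higher number a more lipophilic compound), two compounds sharing one core have numbers so far: compound 1 `C[C@H]1CC[C@@H]2[C@@H](OC(=O)[C@]23CC(c2c(F)cccc2F)N(c2ccccc2)O3)[C@]2(C)C(=O)C=C[C@@]12O` gives 3.42, and compound 2 `C[C@H]1CC[C@@H]2[C@@H](OC(=O)[C@]23CC(c2ccccc2Cl)N(c2ccccc2)O3)[C@]2(C)C(=O)C=C[C@@]12O` gives 3.87, the higher of the two. The next compound, compound 3 `C[C@H]1CC[C@@H]2[C@@H](OC(=O)[C@]23CC(c2ccccc2F)N(c2ccccc2)O3)[C@]2(C)C(=O)C=C[C@@]12O`, differs from compound 2 in one place: fluoro in place of chloro on an aromatic carbon. This is fluoro in place of chloro on an aromatic carbon, ortho to a large group. Among the compounds with values here, only one measured step bears on this change, a number 0.45 log units higher from compound 1 to compound 2 (beyond the scatter), a modest step. It also links a ring bearing fluoro with a ring bearing chloro, but it is not the same change, so it is only a rough guide. Read in reverse, it points to a fall of similar size in this assay when chloro leaves and fluoro enters. The expected move is a number 0.47 log units lower from compound 2 to compound 3 (beyond the scatter). Compound 3 is therefore estimated at 3.4, with an expected range of 3.1 to 3.7.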

Compound 3, partition coefficient: 3.35
Compound 3: middle estimate off by 0.05 log units, on the high side, and the stated range covers the measured number.
By their numbers in this assay, from the lowest: compounds 3 and 1 (each within the scatter of the next); then compound 2.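

In this assay, fluoro in place of chloro on this aromatic carbon gives a clear step (a number 0.52 log units lower from compound 2 to compound 3 (beyond the scatter)), so the choice between these two halogens registers at this place, and the step now comes from a pair differing in that one atom alone. Hydrogen in place of one fluoro on the ring leaves no readable difference (a number 0.07 log units lower from compound 1 to compound 3 (within the scatter)), and compound 2 stands apart as the highest of the three, with its steps to both others beyond the scatter. No measurement shown explains why the chloro compound stands apart.

From the compounds shown here alone, how a bromo, a methyl or a methoxy group on the same aromatic carbon would read remains open. So does whether the step from chloro to fluoro would be of similar size on another carbon of this ring.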